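Notes on compound 3 to compound 4: nitro to fluoro

A few compounds are considered here, and "the series" means these few. Any claim that something is new, unique, unknown or untested is made for them only; others in the source may bear on it.

The series keeps one shared core and varies the group on an amine nitrogen in a ring: compound 1 `CN1C/C(=C\c2cccnc2)C(=O)/C(=C/c2ccccc2C(F)(F)F)C1` carries methyl, compound 2 `Cc1ccc(S(=O)(=O)N2C/C(=C\c3cccnc3)C(=O)/C(=C/c3ccccc3C(F)(F)F)C2)cc1` carries (4-methylphenyl)sulfonyl and compound 3 `O=C1/C(=C/c2cccnc2)CN(S(=O)(=O)c2ccc([N+](=O)[O-])cc2)C/C1=C\c1ccccc1C(F)(F)F` carries (4-nitrophenyl)sulfonyl. In a functional assay on QGY-7703 cells (Homo sapiens) for cytotoxicity, read by MTT assay, with a stated time of 24 h (on this read-out lower numbers stand for stronger inhibition and higher numbers for weaker inhibition), compound 1 gives 2910 nM, compound 2 gives 6170 nM and compound 3 gives 7660 nM. Compound 3 thus stands at the upper end of these numbers, together with compound 2.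

The next compound is compound 4 `O=C1/C(=C/c2cccnc2)CN(S(=O)(=O)c2ccc(F)cc2)C/C1=C\c1ccccc1C(F)(F)F`, with fluoro in place of nitro on an aromatic carbon. The closest measured change is nitro in place of methyl on an aromatic carbon, a 1.2-fold higher number from compound 2 to compound 3 (0.09 log units; within the scatter), which stays within the scatter. The two modest steps, a 2.1-fold higher number from compound 1 to compound 2 (0.33 log units; beyond the scatter) and a 2.6-fold higher number from compound 1 to compound 3 (0.42 log units; beyond the scatter), replace methyl with a whole arylsulfonyl group, a change that compound 4 does not make. Going by the values given here, no fluoro compound has been measured, so the direction remains open, and no step beyond the scatter is expected in this assay. The expected step is a 1.2-fold lower number from compound 3 to compound 4 (0.07 log units; within the scatter). Compound 4 is estimated at 6500 nM, with an expected range from 3500 nM to 11000 nM.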

Compound 4, half-maximal inhibitory concentration: 6030 nM
Compound 4: middle estimate off by 1.1-fold (0.03 log units), on the high side, and the stated range covers the measured number.
By their numbers in this assay, from the lowest: compound 1; then compounds 4, 2 and 3 (each within the scatter of the next).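

At the aromatic carbon para to a large group, three substituents can now be compared in this assay: fluoro in place of nitro gives a 1.3-fold lower number from compound 3 to compound 4 (0.10 log units; within the scatter) and fluoro in place of methyl gives a 1.0-fold lower number from compound 2 to compound 4 (0.01 log units; within the scatter), so compound 2, compound 3 and compound 4 cannot be told apart. Going from nitro to fluoro replaces a larger group bearing hydrogen-bond acceptors with a single atom bearing none, and even this exchange produces no step beyond the scatter at this position. The separation from the methyl compound also holds for the fluoro member, with (4-fluorophenyl)sulfonyl in place of methyl on the amine nitrogen in a ring giving a 2.1-fold higher number from compound 1 to compound 4 (0.32 log units; beyond the scatter), so compound 1 stays apart from all three arylsulfonyl compounds and none of them goes against this.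

No evidence is at hand that accounts for either the flat position or the step from methyl. Still open, as far as these compounds go, is whether an amine or a carboxylic acid at the same aromatic carbon would also stay within the scatter, and whether a longer chain on the amine nitrogen in a ring would read with compound 1 or with the arylsulfonyl compounds.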